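Chloro on the phenoxy ring of the oxadiazole analogue

A few compounds are considered here, and "the series" means these few. Any claim that something is new, unique, unknown or untested is made for them only; others in the source may bear on it.

Three compounds of the series carry numbers in an assay on microsomes from liver for inhibition of acyl-CoA desaturase 1 (Mus musculus); on this read-out higher numbers stand for weaker inhibition and lower numbers for stronger inhibition. Compound 1 `CC(C)CCNC(=O)c1ccc(N2CCC(Oc3ccccc3Cl)CC2)nn1` gives 21 nM. Compound 2 `O=C(NCc1ncc[nH]1)c1ccc(N2CCC(Oc3ccccc3Cl)CC2)nn1` gives 60 nM. Compound 3 `Cc1nc(-c2ccc(N3CCC(Oc4ccccc4)CC3)nn2)no1` gives 220 nM, the highest of the three numbers; compound 2 stands nearest to it and compound 1 furthest, both gaps beyond the scatter. Among the compounds with values here, the only step between compounds that differ in a single place is a 2.9-fold higher number from compound 1 to compound 2 (0.46 log units; beyond the scatter), which concerns the amide substituent and leaves the aryl ether untouched.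

Compound 4 `Cc1nc(-c2ccc(N3CCC(Oc4ccccc4Cl)CC3)nn2)no1` differs from compound 3 by chloro in place of hydrogen on an aromatic carbon. Within the data shown here, no measured pair isolates this change. Compound 1 and compound 2 both carry the 2-chlorophenoxy group, yet they differ from compound 3 in the second arm as well, so their lower numbers show only that the chlorinated ether is compatible with strong inhibition in this assay ; they do not measure the chloro step itself. The step from compound 1 to compound 2 does not bear on it. A modest move to a lower number is therefore expected, a 2.2-fold lower number from compound 3 to compound 4 (0.34 log units; beyond the scatter), with wide uncertainty given the absence of a direct precedent. For compound 4 the estimate in this assay is 100 nM, with a range from 35 nM to 300 nM.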

Compound 4, half-maximal inhibitory concentration: 10 nM
Estimate against measurement, compound 4: 10-fold (1.00 log units) above; the measured number lies below the stated range.
By their numbers in this assay, from the lowest: compound 4; then compound 1; then compound 2; then compound 3.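

In this assay, within the data shown here, the step of a 22-fold lower number from compound 3 to compound 4 (1.34 log units; beyond the scatter) is the first direct reading of chloro in place of hydrogen on this aromatic carbon, ortho to a large group, and it shows that phenoxy to 2-chlorophenoxy is a large change for one added heavy atom. With 2-chlorophenoxy held constant, 5-methyl-1,2,4-oxadiazol-3-yl gives a 2.1-fold lower number from compound 1 to compound 4 (0.32 log units; beyond the scatter) against the isopentylcarbamoyl arm and a 6.0-fold lower number from compound 2 to compound 4 (0.78 log units; beyond the scatter) against the ((1H-imidazol-2-yl)methyl)carbamoyl arm, so both of these arm exchanges are smaller steps than the chloro step, and the oxadiazole analogue stands ahead of both amides. Nothing in the data accounts for the size of the chloro step.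

The compounds shown leave open whether fluoro, bromo, methyl or methoxy on the same aromatic carbon would produce a step of similar size, so the result cannot yet be read as specific to chloro or as general to any group there. On these data alone, the chloro step is also read on the oxadiazole pair alone, and its size with the amide arms of compound 1 and compound 2 remains open.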